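Swapping the aniline ring on a quinoxaline sulfone core

This account rests on a few compounds, and the source may have more. Where it says the series, first, only, none or still open, it means among the compounds named here.

Measured so far in a functional assay on HCT-116 cells (Homo sapiens) for cytotoxicity, read by MTT assay, with a stated time of 72 h; on this read-out higher numbers stand for weaker inhibition and lower numbers for stronger inhibition:
compound 1, `COc1cc(Nc2nc3ccccc3nc2S(=O)(=O)c2ccccc2)cc(OC)c1`: 950 nM
compound 2, `Nc1ccc(Nc2nc3ccccc3nc2S(=O)(=O)c2ccccc2)cc1`: 10800 nM
compound 3, `COc1cc(Nc2nc3ccccc3nc2S(=O)(=O)c2ccc(Br)cc2)cc(OC)c1`: > 50000 nM

All three compounds share a core in which a sulfone-bearing aromatic bicycle carries an aniline-type nitrogen. For compound 3 the assay reports only a limit, > 50000 nM, and not a number; this is marked by the limit of > 50000 nM in this assay, at which 1 of the 3 values shown sits.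

Two changes are shown among the measured compounds. From compound 1 to compound 2 the change is 4-aminophenyl in place of 3,5-dimethoxyphenyl on a nitrogen on an aromatic ring, and in this assay it gave an 11-fold higher number from compound 1 to compound 2 (1.06 log units; beyond the scatter). From compound 1 to compound 3 the change is bromo in place of hydrogen on an aromatic carbon, and here it gave an at least 52-fold higher number from compound 1 to compound 3 (1.72 log units; beyond the scatter).

Compound 4, `Nc1ccc(Nc2nc3ccccc3nc2S(=O)(=O)c2ccc(Br)cc2)cc1`, has not yet been measured. It differs from compound 3 by 4-aminophenyl in place of 3,5-dimethoxyphenyl on a nitrogen on an aromatic ring, which is the same change as the one from compound 1 to compound 2, made on a core that differs by the bromo in place of hydrogen described above. The earlier step, an 11-fold higher number from compound 1 to compound 2 (1.06 log units; beyond the scatter), rests on compound 1 and compound 2 alone. Since compound 3 already sits at the limit of this assay, and the same change weakened compound 1 when it became compound 2, compound 4 is expected to lie at or beyond that limit as well, with an estimated step that the limit leaves unreadable from compound 3 to compound 4. The estimate for compound 4 is 200000 nM, with a range from 50000 nM to 1000000 nM, and it is very likely that the assay will again report only a limit.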

Compound 4, half-maximal inhibitory concentration: 1390 nM
The estimate for compound 4 lay 140-fold (2.16 log units) above the measured number; measured number outside the range, below it.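

In this assay, 4-aminophenyl in place of 3,5-dimethoxyphenyl gave an at least 35-fold lower number from compound 3 to compound 4 (1.55 log units; beyond the scatter), which runs opposite to the same change on the core without bromo, and the two steps differ: the same change on two cores in this assay, an 11-fold higher number (1.06 log units; beyond the scatter) from compound 1 to compound 2 and an at least 35-fold lower number (1.55 log units; beyond the scatter) from compound 3 to compound 4, at least 400-fold (2.61 log units) apart, beyond the scatter of two such steps

Bromo in place of hydrogen also behaved differently on the two cores, giving a 7.8-fold lower number from compound 2 to compound 4 (0.89 log units; beyond the scatter) after the large loss seen when it was added to compound 1, and these two steps differ as well: the same change on two cores in this assay, an at least 52-fold higher number (1.72 log units; beyond the scatter) from compound 1 to compound 3 and a 7.8-fold lower number (0.89 log units; beyond the scatter) from compound 2 to compound 4, at least 400-fold (2.61 log units) apart, beyond the scatter of two such steps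

The value of compound 3, > 50000 nM, is a limit and not a number, so the first of these steps gives only a bound, and the four compounds show that neither change can be carried unchanged from one core to the other, but they do not show why.

From the compounds shown here alone, with only four compounds forming a single square of changes, it remains open whether this reversal is particular to bromo and 4-aminophenyl or extends to other groups. The compounds shown do not tell what chloro or methyl in place of the bromo would do, or how an aniline ring carrying a single methoxy group or a carboxylic acid would behave on either core.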